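This account rests on a few compounds, and the source may have more. Where it says the series, first, only, none or still open, it means among the compounds named here.

In a functional assay on the whole organism for activation, with Mus musculus as the target, with a stated time of 60 min (a lower number here means that less compound is needed, a higher number that more compound is needed for the effect), compound 1 `N#Cc1ccc(-c2ccc(/C=N/N3C(=O)NC(=O)C3O)o2)cc1` gives 156 mg/kg. For compound 2 `Nc1ccc(-c2ccc(/C=N/N3C(=O)NC(=O)C3O)o2)cc1`, this assay gives only a limit, > 1000 mg/kg. Compound 3 `O=C1NC(=O)N(/N=C/c2ccc(-c3ccc([N+](=O)[O-])cc3)o2)C1O` has nitro in place of amino on an aromatic carbon, para to a large group: nitro in place of amino on an aromatic carbon. For the measured compounds named here, one measured step bears on this change, an at least 6.4-fold higher number from compound 1 to compound 2 (0.80 log units; beyond the scatter), where amino took the place of cyano on an aromatic carbon. Nitro is not cyano, so that step is only a partial guide, but a similar drop in the number is expected once amino leaves, and the expected change is an at least 6.6-fold lower number from compound 2 to compound 3 (0.82 log units; beyond the scatter). The estimate for compound 3 is 150 mg/kg, with a range of 50 mg/kg to 450 mg/kg.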

Compound 3, dose for half-maximal effect: > 1000 mg/kg
Compound 3: no number, only a limit; the forecaster's own chance of this, stated with the estimate: 15%; middle value at least 6.6-fold (0.82 log units) away from the limit.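

In this assay, putting nitro in place of cyano gives an at least 6.4-fold higher number from compound 1 to compound 3 (0.80 log units; beyond the scatter), so on this aromatic carbon the loss seen with amino is not specific to amino. Of the three groups shown here, only cyano gives a measured number, while amino and nitro both end in a limit. The step between compound 2 and compound 3 cannot be read, since both values are limits: the limit of > 1000 mg/kg in this assay, at which 2 of the 3 values shown sit.

For the compounds shown here, with only one measured number at this position, the size of the loss remains open. So does how a trifluoromethyl group or a carboxylic acid on the same carbon would compare with cyano.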